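A few compounds are considered here, and "the series" means these few. Any claim that something is new, unique, unknown or untested is made for them only; others in the source may bear on it.

In a functional assay on A549 cells (Homo sapiens) for inhibition (on this read-out lower numbers stand for stronger inhibition of growth and higher numbers for weaker inhibition of growth), compound 1 `CC(C)(C)c1ccc(S(=O)(=O)Nc2cccc(O)c2)cc1` gives 12000 nM. Compound 2 `Cc1ccccc1NS(=O)(=O)c1ccc(C(C)(C)C)cc1` has only a limit, > 80000 nM. Among the measured compounds shown here, the one measured step that bears on what follows is an at least 6.6-fold higher number from compound 1 to compound 2 (0.82 log units; beyond the scatter), with 2-methylphenyl in place of 3-hydroxyphenyl on a sulfonamide nitrogen. Compound 3 `Cc1cccc(NS(=O)(=O)c2ccc(C(C)(C)C)cc2)c1` carries 3-methylphenyl in place of 2-methylphenyl at that nitrogen: 3-methylphenyl in place of 2-methylphenyl on a sulfonamide nitrogen. It thus shares the 3-substituted pattern of compound 1, so on the strength of an at least 6.6-fold higher number from compound 1 to compound 2 (0.82 log units; beyond the scatter) a modest move towards a lower number is expected, and the expected change is an at least 2.2-fold lower number from compound 2 to compound 3 (0.35 log units; beyond the scatter). For compound 3 the estimated value is 35000 nM, with an expected range of 12000 nM to 80000 nM.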

Compound 3, concentration for 50% growth inhibition: 80000 nM
The estimate for compound 3 lay 2.3-fold (0.36 log units) below the measured number, within the range that was stated.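

With 3-methylphenyl on the sulfonamide nitrogen, the step from the hydroxy compound changes only the group, not its place: methyl in place of hydroxy on an aromatic carbon gives a 6.7-fold higher number from compound 1 to compound 3 (0.82 log units; beyond the scatter). The earlier step had changed the group and its place together, whereas this one shows that the 3-substituted pattern alone does not hold the number of compound 1. The step between the two methyl isomers is a number no higher from compound 2 to compound 3 (the limit leaves the size open). Its size cannot be read, because compound 2 has only a limit: the limit of > 80000 nM in this assay, at which 1 of the 3 values shown sits.

Open, on these data alone, is whether an amino group or a methoxy group in place of the hydroxy would keep the number of compound 1.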